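The compounds below may be only part of what the source reports. "The series", "measured", "known", "first", "only" and "open" are said of these compounds alone.

Measured so far:
compound 1, `O=C(Nc1nc(-c2ccccc2)nc2c1nnn2Cc1ccccc1)c1ccoc1` — 10 nM
compound 2, `O=C(Nc1nc(-c2ccccc2)nc2c1nnn2Cc1ccccc1)C1CCCC1` — 2.5 nM

Both numbers come from an assay (strain Wistar) for displacement of a labelled ligand from adenosine receptor A1 (Rattus norvegicus), read by scintillation counting; a higher number here means a weaker inhibitor, a lower number a stronger inhibitor. Among the compounds with values here, compound 2 carries the lower of the two numbers; its only neighbour is compound 1, and the single step between them, a 4.0-fold lower number from compound 1 to compound 2 (0.60 log units; beyond the scatter), is the whole of the measured ground so far. Compound 3, `O=C(Nc1nc(-c2ccccc2)nc2c1nnn2Cc1ccccc1)C1CC1`, is not yet measured. It differs from compound 2 in one place: cyclopropyl in place of cyclopentyl on a carbonyl carbon. Within the data shown here, no measured step exchanges one non-aromatic ring for another on the carbonyl carbon; the one step that touches this position, a 4.0-fold lower number from compound 1 to compound 2 (0.60 log units; beyond the scatter), swaps an aromatic ring for a non-aromatic one and so bears on the question only loosely. It shows that a change of ring at this position is tolerated without a large shift in either direction. For the move to the smaller ring a small step in this assay is expected, more likely towards a higher number than a lower one, and possibly none beyond the scatter; the expected step is a 2.0-fold higher number from compound 2 to compound 3 (0.30 log units; within the scatter). Compound 3 is therefore estimated at 5 nM, with a range from 1.5 nM to 20 nM.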

Compound 3, inhibition constant: 7.5 nM
Beside the measured number, compound 3's estimate is 1.5-fold (0.18 log units) below it, within the range that was stated.
By their numbers in this assay, from the lowest: compound 2; then compounds 3 and 1 (each within the scatter of the next).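

In this assay, the exchange of one non-aromatic carbon ring for another on the carbonyl carbon gives a step beyond the scatter (a 3.0-fold higher number from compound 2 to compound 3 (0.48 log units; beyond the scatter)), so the number at this position depends on which non-aromatic ring is present and not only on whether the ring is aromatic. The cyclopropyl and furan-3-yl compounds cannot be told apart (a 1.3-fold lower number from compound 1 to compound 3 (0.12 log units; within the scatter)), so the lower number seen for cyclopentyl in compound 2 does not extend to every non-aromatic ring in this small set, and compound 2 is now the strongest of the three, with its steps to both others beyond the scatter. Nothing on hand explains either step.

From the compounds shown here alone, two ring sizes cannot define a trend, so it remains open how cyclobutyl or cyclohexyl would sit relative to cyclopentyl and cyclopropyl on this carbonyl carbon. Also open, going by these compounds, is whether a ring is needed at all, which an open chain such as tert-butyl, or a group bearing an amine or a carboxylic acid, would test at the same place.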